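The source may report more compounds than this note shows. Statements on the series, on what has been measured and on what is new or still open speak of the compounds shown alone.

Measured compounds:
- Compound 1, `O=C(CSc1nnc(-c2ccncc2)n1-c1ccccc1)N/N=C/c1ccc(Cl)cc1`: in a functional assay on MCF7 cells (Homo sapiens) for inhibition, read by MTT assay, with a stated time of 48 h (a higher number here means a weaker inhibitor, a lower number a stronger inhibitor), compound 1 gives 9930 nM
- Compound 2, `O=C(CSc1nnc(-c2ccncc2)n1-c1ccccc1)N/N=C/c1ccccc1O`: in this assay compound 2 gives 10000 nM

Among the compounds with values here, compound 2 stands at the higher of the two numbers so far, but only nominally: the one measured step, a 1.0-fold higher number from compound 1 to compound 2 (0.00 log units; within the scatter), lies within the scatter, so the two compounds cannot be told apart on these numbers.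

Compound 3, `O=C(CSc1nnc(-c2ccncc2)n1-c1ccccc1)N/N=C/c1ccc(O)c(O)c1`, differs from compound 2 in a single place: 3,4-dihydroxyphenyl in place of 2-hydroxyphenyl on a carbon with a double bond to nitrogen. The shared core, with its thioether linker and hydrazone, is untouched.

Within the data shown here, the only step that bears on this change is a 1.0-fold higher number from compound 1 to compound 2 (0.00 log units; within the scatter). It also exchanges the aromatic group on the carbon with a double bond to nitrogen, and it produced no shift beyond the scatter. On that basis no step beyond the scatter is expected in this assay for compound 3 either, which means a step of about no change at the digits printed from compound 2 to compound 3 (within the scatter) is expected from compound 2 to compound 3. Compound 3 is therefore estimated at 10000 nM, with a likely range from 4000 nM to 25000 nM.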

Compound 3, half-maximal inhibitory concentration: 19700 nM
Compound 3: middle estimate off by 2.0-fold (0.29 log units), on the low side, and the stated range covers the measured number.
By their numbers in this assay, from the lowest: compounds 1, 2 and 3 (each within the scatter of the next).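

In this assay, replacing the 2-hydroxyphenyl group with 3,4-dihydroxyphenyl gives a 2.0-fold higher number from compound 2 to compound 3 (0.29 log units; within the scatter), and replacing the 4-chlorophenyl group with it gives a 2.0-fold higher number from compound 1 to compound 3 (0.30 log units; within the scatter), so neither step separates the compounds. The position on the carbon with a double bond to nitrogen has now held three different substituted phenyl groups, and these three compounds cannot be told apart, whether the ring carries a chlorine, one hydroxyl group or two. No measurement is available that would explain these numbers.

Going by these compounds, all three compounds keep a phenyl ring at this position, so it remains open whether a ring carrying an amine or a carboxylic acid, or a longer alkyl chain in place of the ring, would produce a step beyond the scatter. The shared core is also the same throughout, so these compounds cannot show whether replacing the thioether linker or the hydrazone would change the number.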